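Halo swap on the fused ring: cytotoxicity notes

The compounds below may be only part of what the source reports. "The series", "measured", "known", "first", "only" and "open" are said of these compounds alone.

Measured compounds:
- compound 1 `CONC(=S)N/N=C1\C(=O)N(CN2CCN(c3ccc(Cl)cc3)CC2)c2ccc(Cl)cc21` — 229000 nM
- compound 2 `CCn1cc(C(=O)O)c(=O)c2cc(F)c(N3CCN(CN4C(=O)/C(=N\NC(=S)NO)c5cc(Cl)ccc54)C(C)C3)c(F)c21` — 209000 nM
- compound 3 `CONC(=S)N/N=C1\C(=O)N(CN2CCN(c3ccc(Cl)cc3)CC2)c2ccc(F)cc21` — 347000 nM

The three measured compounds were all run in an ADME assay on MT4 cells (Homo sapiens) for cytotoxicity, read by spectrophotometry, with a stated time of 5 days; a higher number here means that more compound is tolerated, a lower number that less compound is tolerated. Compound 1 gives 229000 nM, compound 3 gives 347000 nM, and compound 2 gives 209000 nM in this assay. All three numbers lie within the usual scatter of one another, so no ordering among them is claimed.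

Compound 1 and compound 3 differ in a single place, (fluoro in place of chloro on an aromatic carbon). The step of a 1.5-fold higher number from compound 1 to compound 3 (0.18 log units; within the scatter). Compound 2 carries a different core from compound 1; the difference between the two cores is not broken down here.

Compound 4 `CCn1cc(C(=O)O)c(=O)c2cc(F)c(N3CCN(CN4C(=O)/C(=N\NC(=S)NO)c5cc(F)ccc54)C(C)C3)c(F)c21` has not yet been measured in this assay. It stands to compound 2 as compound 3 stands to compound 1: fluoro in place of chloro on an aromatic carbon. The place of the change is the same in both pairs, so this is the same change made once more, on the core of compound 2.

For compound 4 in this assay, the step of a 1.3-fold higher number from compound 2 to compound 4 (0.11 log units; within the scatter) is expected, matching the earlier step in size, because a 1.5-fold higher number from compound 1 to compound 3 (0.18 log units; within the scatter). Since that earlier step sat within the scatter, the expectation for compound 4 is a number close to that of compound 2 rather than a clear shift. The estimate for compound 4 is 270000 nM, with a likely range from 150000 nM to 480000 nM.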

Compound 4, half-maximal cytotoxic concentration: 187000 nM
Beside the measured number, compound 4's estimate is 1.4-fold (0.16 log units) above it, and the stated range covers the measured number.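

In this assay, fluoro in place of chloro on an aromatic carbon of the core of compound 2 gives a 1.1-fold lower number from compound 2 to compound 4 (0.05 log units; within the scatter). Set beside the same change on the core of compound 1, the new step does not differ from the earlier one: the same change on two cores in this assay, a 1.5-fold higher number (0.18 log units; within the scatter) from compound 1 to compound 3 and a 1.1-fold lower number (0.05 log units; within the scatter) from compound 2 to compound 4, 1.7-fold (0.23 log units) apart, within the scatter of two such steps. On these two cores, the change therefore stays within the scatter each time and the steps agree, but this is agreement between two steps too small to read, so it shows neither a real effect of the change nor a direction that carries from one core to the other.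

The compounds shown have only chloro or fluoro at this place, so it remains open whether a group such as nitrile or trifluoromethyl on the same aromatic carbon would give a step beyond the scatter in this assay on either core. Also open, as far as these compounds go, is whether the agreement seen on these two cores would hold on a third core, or in any read-out other than tolerance of the compounds by these cells.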